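Fluorophenyl to pyridyl on a shared dienone scaffold

A few compounds are considered here, and "the series" means these few. Any claim that something is new, unique, unknown or untested is made for them only; others in the source may bear on it.

Compound 1 `CC1=C(/C=C/C(=O)/C=C/c2ccccc2)C(C)(C)CCC1` and compound 2 `CC1=C(/C=C/C(=O)/C=C/c2ccccc2F)C(C)(C)CCC1` share the same core and differ only at the aromatic end. In a functional assay on IMR-32 cells (Homo sapiens) for cytotoxicity, read by sulforhodamine B assay, with a stated time of 48 h (on this read-out lower numbers stand for stronger inhibition and higher numbers for weaker inhibition), compound 1 gives 20400 nM and compound 2 gives 15600 nM; the step of a 1.3-fold lower number from compound 1 to compound 2 (0.12 log units; within the scatter), so the two numbers lie within the scatter of each other. Compound 3 `CC1=C(/C=C/C(=O)/C=C/c2cccnc2)C(C)(C)CCC1` carries pyridin-3-yl in place of 2-fluorophenyl on a double-bonded chain carbon bound to a double-bonded chain carbon. For the measured compounds named here, no measured step exchanges the ring itself, and the only known step, a 1.3-fold lower number from compound 1 to compound 2 (0.12 log units; within the scatter), stayed within the scatter, so no shift beyond the scatter is expected in this assay. Compound 3 is estimated at 17000 nM, between 6000 nM and 50000 nM. That expectation amounts to a step of a 1.1-fold higher number from compound 2 to compound 3 (0.04 log units; within the scatter).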

Compound 3, half-maximal inhibitory concentration: 25300 nM
The estimate for compound 3 lay 1.5-fold (0.17 log units) below the measured number; low and high end bracket the measured number.
By their numbers in this assay, from the lowest: compounds 2, 1 and 3 (each within the scatter of the next).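

In this assay, unlike the fluoro step, this change exchanges the ring itself and brings in a ring nitrogen, yet a 1.6-fold higher number from compound 2 to compound 3 (0.21 log units; within the scatter) and a 1.2-fold higher number from compound 1 to compound 3 (0.09 log units; within the scatter) both stay within the scatter. At this place on the shared core, phenyl, 2-fluorophenyl and pyridin-3-yl thus give numbers that cannot be told apart, so even a change of ring atom does not separate these compounds here.

Going by these compounds, whether a phenyl ring bearing an amine or a carboxylic acid, or a longer chain in place of the ring, would move the number beyond the scatter stays open. Nothing available explains why these three compounds read alike.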